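Para substituent on the benzyl piperidine: fluoro to benzyloxy

This account rests on a few compounds, and the source may have more. Where it says the series, first, only, none or still open, it means among the compounds named here.

Compound 1 `COc1cc(N)c(Cl)cc1NC(=O)C1CCN(CC2CC2)CC1` reaches only a limit of > 10 mg/kg in a functional assay on the whole organism for antagonist activity, with Mus musculus as the target; a lower number here means that less compound is needed, a higher number that more compound is needed for the effect. Compound 2 `COc1cc(N)c(Cl)cc1NC(=O)C1CCN(Cc2ccccc2Cl)CC1` likewise gives only a limit of > 4 mg/kg in this assay. Within the data shown here, compound 3 `COc1cc(N)c(Cl)cc1NC(=O)C1CCN(Cc2ccc(F)cc2)CC1` is the sole compound with a number, 0.6 mg/kg in this assay. The steps to it were an at least 16-fold lower number from compound 1 to compound 3 (1.22 log units; beyond the scatter) and an at least 6.6-fold lower number from compound 2 to compound 3 (0.82 log units; beyond the scatter), while a step that the two limits leave unreadable from compound 1 to compound 2. Compound 4 `COc1cc(N)c(Cl)cc1NC(=O)C1CCN(Cc2ccc(OCc3ccccc3)cc2)CC1` differs from compound 3 as follows: benzyloxy in place of fluoro on an aromatic carbon. Among the measured compounds shown here, no measured step varies the group at this position on the benzyl ring, so the measured steps give no direct guide. For compound 4 a step of a 2.5-fold higher number from compound 3 to compound 4 (0.40 log units; beyond the scatter) is expected, modest and within or near the scatter. Compound 4 is estimated at 1.5 mg/kg, range 0.4 mg/kg to 6 mg/kg.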

Compound 4, dose for half-maximal effect: > 4 mg/kg
Compound 4: only a limit was reported; the forecaster's own chance of this, stated with the estimate: 15%; middle value at least 2.6-fold (0.42 log units) away from the limit.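

Among these compounds, the first measured change at this aromatic carbon gives an at least 6.6-fold higher number from compound 3 to compound 4 (0.82 log units; beyond the scatter) in this assay, so benzyloxy does not stand in for fluoro here without cost. Compound 4 reaches only a limit, so this step is a minimum and its full size cannot be read: the limit of > 4 mg/kg in this assay, at which 2 of the 4 values shown sit.

Whether the added aromatic ring or the ether oxygen accounts for the step remains open. A methoxy or a methyl group on this carbon would show whether anything other than fluoro keeps a measurable dose.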